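A few compounds are considered here, and "the series" means these few. Any claim that something is new, unique, unknown or untested is made for them only; others in the source may bear on it.

The measured compounds are:
compound 1 `O=C(O)CN(Cc1ccc(Cl)cc1)Cc1ccc([N+](=O)[O-])s1`: "not determined" (no result reported);
compound 2 `O=[N+]([O-])c1ccc(CN(Cc2ccc(Cl)cc2)Cc2nc3ccccc3s2)s1`: 4000 nM;
compound 3 `CN1CCC(CN(Cc2ccc(Cl)cc2)Cc2ccc([N+](=O)[O-])s2)C1`: "not determined" (no result reported).

All three were examined in a functional assay on HEK293 cells for agonist activity at nuclear receptor subfamily 1 group D member 1 (Homo sapiens), read by a luciferase reporter, with a stated time of 24 h; a higher number here means that more compound is needed for the effect, a lower number that less compound is needed. Only compound 2 has a number there, 4000 nM. Compound 3 has no single number in this assay, and compound 1 likewise lacks one, so compound 3 cannot be placed against the others on the numbers shown. Compound 4 `O=C(Nc1ccc([N+](=O)[O-])cc1)N1CCC(CN(Cc2ccc(Cl)cc2)Cc2ccc([N+](=O)[O-])s2)C1` has not yet been measured. It differs from compound 3 in one place: (4-nitrophenyl)carbamoyl in place of methyl on an amine nitrogen in a ring. Among the compounds with values here, no step between measured compounds is available, so the size and direction of the change that this substitution brings in this assay cannot be read from a neighbouring pair, and with compound 3 lacking a number, no direction relative to it can be stated. Within the data shown here, the only anchor is compound 2, which shares much of its structure with the unmeasured compound; in this assay compound 2 gives 4000 nM. On that anchor alone, compound 4 is expected to fall near 2500 nM, with a plausible range from 500 nM to 12000 nM.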

Compound 4, half-maximal effective concentration: 400 nM
Compound 4: the middle estimate sits 6.3-fold (0.80 log units) above what was measured, outside the stated range (below it).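

No new step can be read, since compound 4 gives 400 nM in this assay while compound 3 has no single number there. The compounds shown leave open what the (4-nitrophenyl)carbamoyl group contributes to this value. No evidence shown bears on this result.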